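This account rests on a few compounds, and the source may have more. Where it says the series, first, only, none or still open, it means among the compounds named here.

In a functional assay on the whole organism with Mus musculus as the target, in the rotarod test (on this read-out higher numbers stand for an effect only at larger amounts of compound and lower numbers for an effect already at smaller amounts), compound 2 `O=C(/C=C1\CCc2ccccc21)NC1CC1` gives 235 mg/kg. That lies within the usual scatter of compound 3 `O=C(/C=C1\CCc2cc(F)ccc21)NC1CC1`, which gives 193 mg/kg, and both numbers stand well above compound 1 `Cc1cccc2c1CC/C2=C\C(=O)NC1CC1`, which gives 64 mg/kg. Compound 4 `O=C(/C=C1\CCc2c(Cl)cccc21)NC1CC1` has not yet been measured. It differs from compound 2 by one change: chloro in place of hydrogen on an aromatic carbon.

Within the data shown here, two measured steps bear on this change, and both concern a group on an aromatic carbon. The closer guide is the methyl of compound 1, which, like the chloro of compound 4, sits ortho to a fused ring and meta to a fused ring. Removing it gives a 3.7-fold higher number from compound 1 to compound 2 (0.56 log units; beyond the scatter), so adding a group there may lower the number. The fluoro of compound 3 sits elsewhere, and its step, a 1.2-fold lower number from compound 2 to compound 3 (0.09 log units; within the scatter), stays within the scatter. Chloro itself has not been tested in this series, so only part of the methyl step is expected to carry over, in the same direction. The expected change is a 2.4-fold lower number from compound 2 to compound 4 (0.37 log units; beyond the scatter), a modest one. For compound 4 the estimated value is 100 mg/kg, with an expected range from 45 mg/kg to 220 mg/kg.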

Compound 4, dose for half-maximal effect: 66 mg/kg
The estimate for compound 4 lay 1.5-fold (0.18 log units) above the measured number; measured number inside the range.
By their numbers in this assay, from the lowest: compounds 1 and 4 (each within the scatter of the next); then compounds 3 and 2 (each within the scatter of the next).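

At this place, on an aromatic carbon ortho to a fused ring and meta to a fused ring, chloro in place of hydrogen gives a 3.6-fold lower number from compound 2 to compound 4 (0.55 log units; beyond the scatter) in this assay, so the effect at smaller amounts seen with methyl is now seen with a second, quite different group. Putting chloro in place of methyl gives a 1.0-fold higher number from compound 1 to compound 4 (0.01 log units; within the scatter), which means that this read-out does not tell the two groups apart at this place, and the gain over hydrogen is therefore not tied to methyl alone. The compounds shown offer no measurement that explains why either group lowers the number.

Going by these compounds, what remains open is whether the place or the group decides the outcome, since fluoro sits at a different place and gives only a 1.2-fold lower number from compound 2 to compound 3 (0.09 log units; within the scatter), leaving unknown what fluoro would do at the place held by chloro, or chloro at the place held by fluoro. On these data alone, it is also open whether a methoxy group, an amine or a carboxylic acid at this place would lower the number in the same way or would break the pattern shared by methyl and chloro.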